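The source may hold more compounds than are shown below. What is called first, only, known or untested is meant among the compounds shown, and "the series" means these compounds.

Of the compounds shown here, three built on one shared core have been tested in an assay on HEK293 cells for inhibition of Voltage-dependent T-type calcium channel subunit alpha-1G (Homo sapiens), read by fluorescence, tested at 10 uM; a lower number here means less inhibition, a higher number more inhibition at the concentration tested (going by the name of the read-out). In this assay compound 1 `CCCc1nc(-c2ccccc2)c(CNCCN2CCN(c3ccccc3F)CC2)o1` gives 46.5%, compound 2 `CCCc1nc(-c2ccccc2)c(CNCCN2CCN(c3cccc(C)c3)CC2)o1` gives 43.1%, and compound 3 `CCCc1nc(-c2ccccc2)c(CNCCCN2CCN(c3cccc(C)c3)CC2)o1` gives 47.8%, so the three numbers sit close together. Compound 1 and compound 2 differ in a single place, (2-fluorophenyl in place of 3-methylphenyl on an amine nitrogen in a ring), and that change made a step of a number 3.4 percentage points higher from compound 2 to compound 1 (within the scatter). Compound 3 and compound 2 also differ, but the difference between their two cores is not broken down here. Compound 4 `CCCc1nc(-c2ccccc2)c(CNCCCN2CCN(c3ccccc3F)CC2)o1` has not yet been measured in this assay. It arises from compound 3 by the same change, (2-fluorophenyl in place of 3-methylphenyl on an amine nitrogen in a ring), at a place described in exactly the same words as before. Because the earlier step of a number 3.4 percentage points higher from compound 2 to compound 1 (within the scatter) stayed within the scatter, a similarly small step is expected here too, a number 2.2 percentage points higher from compound 3 to compound 4 (within the scatter). Compound 4 is therefore estimated to give about 50% in this assay, with a likely range from 36% to 64%. This expectation rests on one measured pair alone and now awaits the measurement.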

Compound 4, a percentage reported as inhibition, at one concentration (the size of the read-out at that concentration, not a potency): 54.4%
For compound 4 the middle estimate is 4.4 percentage points below the measured one; the measured number falls inside the stated range.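

In this assay, the same swap of 3-methylphenyl for 2-fluorophenyl on the second core gives a small step, a number 6.6 percentage points higher from compound 3 to compound 4 (within the scatter). Set beside the first pair, the change behaves alike on both cores, with no sign that the core alters its outcome: the same change on two cores in this assay, a number 3.4 percentage points higher (within the scatter) from compound 2 to compound 1 and a number 6.6 percentage points higher (within the scatter) from compound 3 to compound 4, 3.2 percentage points apart, within the scatter of two such steps. Going by these compounds alone, this shows only that the swap leaves the read-out within the usual scatter on these two closely related cores; it does not show that 2-fluorophenyl truly gives more inhibition than 3-methylphenyl, and two pairs cannot establish that the result will carry over to other cores.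

The compounds shown leave open what a plain phenyl, a chlorophenyl or a methoxyphenyl group would do in this same place on the ring nitrogen. They also leave open whether the swap would still give so small a step on a core with a longer chain joining the two amine nitrogens.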